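Methylation of the Sulfonamide Nitrogen in a Hydrazone Series

The compounds below may be only part of what the source reports. "The series", "measured", "known", "first", "only" and "open" are said of these compounds alone.

The measured compounds:
compound 1, `Cc1ccc([N+](=O)[O-])cc1S(=O)(=O)N(C)/N=C/c1cnn2ccc(Cl)cc12`, 390 nM in an assay on isolated protein for inhibition of phosphatidylinositol 4,5-bisphosphate 3-kinase catalytic subunit beta isoform (Homo sapiens), read by 33P incorporation, with a stated time of 60 min; a higher number here means a weaker inhibitor, a lower number a stronger inhibitor
compound 2, `CCC/C(=N\NS(=O)(=O)c1cc([N+](=O)[O-])ccc1C)c1cnn2ccc(C#N)cc12`, > 1000 nM

In this assay compound 1 gives 390 nM. For compound 2 the reading is a limit of the assay, not a number: compound 2 gives > 1000 nM, which is the limit of > 1000 nM in this assay, at which 1 of the 2 values shown sits. Compound 2 therefore stands only at the weak end of the numbers shown, and its distance from compound 1 cannot be told.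

Compound 3, `CCC/C(=N\N(C)S(=O)(=O)c1cc([N+](=O)[O-])ccc1C)c1cnn2ccc(C#N)cc12`, is not yet measured. It differs from compound 2 by methyl in place of hydrogen on a sulfonamide nitrogen, a methyl in place of hydrogen on a sulfonamide nitrogen. Among the compounds with values here, no measured pair in this set shows the effect of that change alone, so no size or direction for the step is established. Compound 1 carries a methyl on the same nitrogen and gives 390 nM, but it also differs from compound 2 elsewhere, so this is only a loose pointer.

The step from compound 2 to compound 3 is expected to be a step that the limit leaves unreadable from compound 2 to compound 3. Compound 3 is estimated at 1500 nM, in the range 400 nM to 6000 nM.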

Compound 3, half-maximal inhibitory concentration: > 1000 nM
Compound 3: a limit, no number; the forecaster's own chance of this, stated with the estimate: 50%; the middle value lies beyond the limit too.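

In this assay, within the data shown here, compound 3 gives > 1000 nM, a limit and not a number, and compound 2 also stands at a limit, so no step between them can be read: the limit of > 1000 nM in this assay, at which 2 of the 3 values shown sit. The compounds shown leave open whether methyl in place of hydrogen on a sulfonamide nitrogen changes the reading at all.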